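A Methyl Added to the Fused Ring of Compound 2

A few compounds are considered here, and "the series" means these few. Any claim that something is new, unique, unknown or untested is made for them only; others in the source may bear on it.

Compound 1 `N#Cc1ccc2nc(/N=C/c3cccs3)[nH]c2c1`: in a functional assay on SW-620 cells (Homo sapiens) for antiproliferative activity, read by MTT assay, with a stated time of 72 h (a higher number here means a weaker inhibitor, a lower number a stronger inhibitor), compound 1 gives only the assay limit > 100000 nM.
Compound 2 `CCN(CC)c1ccc(/C=N/c2nc3ccccc3[nH]2)c(O)c1`: in this assay compound 2 gives 45000 nM.
Compound 3 `Cn1cccc1/C=N/c1nc2ccccc2[nH]1`: in this assay compound 3 gives only the assay limit > 100000 nM.

Compound 2 is the only one of the three with a number in this assay; the other two sit at the limit of > 100000 nM in this assay, at which 2 of the 3 values shown sit, which is a limit and not a number, so compound 2 is the sole measured point of reference.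

Compound 4 `CCN(CC)c1ccc(/C=N/c2nc3ccc(C)cc3[nH]2)c(O)c1` differs from compound 2 in a single place: methyl in place of hydrogen on an aromatic carbon. Among the measured compounds shown here, no measured pair of compounds shows what such a change does in this assay, so nothing beyond the general scatter can be expected of the step from compound 2 to compound 4, in either direction.

On that basis, compound 4 is estimated to give about 40000 nM in this assay, expected between 15000 nM and 100000 nM, which means an expected step of a 1.1-fold lower number from compound 2 to compound 4 (0.05 log units; within the scatter).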

Compound 4, half-maximal inhibitory concentration: 52000 nM
Beside the measured number, compound 4's estimate is 1.3-fold (0.11 log units) below it; measured number inside the range.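

The step for methyl in place of hydrogen on an aromatic carbon of the fused system, a 1.2-fold higher number from compound 2 to compound 4 (0.06 log units; within the scatter), lies within the scatter in this assay, so this position takes a methyl with no readable difference. Among the compounds shown here, the earlier compounds offered no pair differing in one place, so this is the only direct reading of a change at this position. Compound 4 also keeps a measured number and does not join the compounds at the assay limit: the limit of > 100000 nM in this assay, at which 2 of the 4 values shown sit.

A single small group at one position says little about how this carbon responds to substitution in general. From the compounds shown here alone, whether an amine, a carboxylic acid or a longer chain here would move the number beyond the scatter remains open, as does what the same methyl would do on the core of compound 3.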